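The source may hold more compounds than are shown below. What is called first, only, known or untested is meant among the compounds shown, and "the series" means these compounds.

The three measured compounds share one core. Compound 1 `Cn1c(-c2cccc(C#N)c2)cnc1NC(=O)c1ccc(F)cc1` carries a 4-fluorophenyl on the carbonyl carbon, compound 2 `Cn1c(-c2cccc(C#N)c2)cnc1NC(=O)c1ncc[nH]1` carries a 1H-imidazol-2-yl there instead, and compound 3 `COc1ccc(-c2cnc(NC(=O)c3ccc(C)cc3)n2C)cc1` is the third member. In a toxicity assay on THP-1 cells (Homo sapiens) for inhibition (a higher number here means that more compound is tolerated, a lower number that less compound is tolerated), compound 1 reaches only the limit > 100000 nM. In this assay compound 2 likewise reaches only the limit > 50000 nM. Compound 3 in this assay also gives only the limit > 100000 nM. For the measured compounds named here, the single measured step, a step that the two limits leave unreadable from compound 1 to compound 2, therefore cannot be sized. Compound 2 stands among limits alone: the limit of > 100000 nM in this assay, at which 2 of the 3 values shown sit, and the limit of > 50000 nM in this assay, at which 1 of the 3 values shown sits, cover every value shown, so no ordering of the three is possible. Compound 4 `Cn1c(-c2cccc(Cl)c2)cnc1NC(=O)c1ncc[nH]1` differs from compound 2 by chloro in place of cyano on an aromatic carbon. Going by the values given here, no measured step bears on this change, and since every member so far is tolerated up to a limit, compound 2 included at > 50000 nM, no shift beyond the scatter is expected in this assay. The step that the limit leaves unreadable from compound 2 to compound 4 is thus expected to be negligible. Compound 4 is estimated at 80000 nM, within 30000 nM to 150000 nM.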

Compound 4, half-maximal cytotoxic concentration: 55000 nM
The estimate for compound 4 lay 1.5-fold (0.16 log units) above the measured number, within the range that was stated.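

No step can be read between compound 2 and compound 4: in this assay compound 2 gives only the limit > 50000 nM. The compounds shown leave open whether chloro in place of cyano on an aromatic carbon shifts the tolerated concentration at all.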